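The compounds below may be only part of what the source reports. "The series", "measured", "known", "first", "only" and "open" are said of these compounds alone.

Compound 1 `C[Se]/C(=N\C(=O)c1cccs1)NC(=O)c1cccs1` gives 6070 nM in a functional assay on K562 cells (Homo sapiens) for cytotoxicity, read by MTT assay, with a stated time of 72 h; on this read-out lower numbers stand for stronger inhibition of growth and higher numbers for weaker inhibition of growth. Compound 2 `CS/C(=N\C(=O)c1cccs1)NC(=O)c1cccs1` gives 72600 nM in this assay. Compound 3 `CS/C(=N\C(=O)c1cc(-c2ccccc2)nc2ccccc12)NC(=O)c1cc(-c2ccccc2)nc2ccccc12` gives 34400 nM in this assay.

Compound 1 and compound 2 share a core and differ in a single place: a group of 2 heavy atoms (1 carbon, 1 selenium; no ring) in place of a group of 2 heavy atoms (1 carbon, 1 sulfur; no ring), on a carbon with a double bond to nitrogen. That one exchange made a large difference, a 12-fold lower number from compound 2 to compound 1 (1.08 log units; beyond the scatter), a step well beyond the usual scatter of repeated measurements. Compound 3 is built on a different core; the difference between the core of compound 2 and the core of compound 3 is not broken down here, so nothing can be said about what it does beyond the two values themselves, which show compound 3 as the somewhat lower number of the two.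

Compound 4 `C[Se]/C(=N\C(=O)c1cc(-c2ccccc2)nc2ccccc12)NC(=O)c1cc(-c2ccccc2)nc2ccccc12` has not yet been measured. It is related to compound 3 exactly as compound 1 is related to compound 2: the change is a group of 2 heavy atoms (1 carbon, 1 selenium; no ring) in place of a group of 2 heavy atoms (1 carbon, 1 sulfur; no ring), on a carbon with a double bond to nitrogen, and it sits at the same place, described in the same words, so this is the same change carried onto a second core.

Because the same change gave a 12-fold lower number from compound 2 to compound 1 (1.08 log units; beyond the scatter) on the first core, a step of comparable size is expected on the second core as well, that is, an 11-fold lower number from compound 3 to compound 4 (1.06 log units; beyond the scatter) is the expected outcome. This expectation rests on a single measured pair, so it carries real uncertainty. For compound 4 the estimate in this assay is 3000 nM, with a likely range from 900 nM to 10000 nM.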

Compound 4, concentration for 50% growth inhibition: 5800 nM
Compound 4: the middle estimate sits 1.9-fold (0.29 log units) below what was measured; measured number inside the range.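

In this assay, placing the selenium-bearing group where methylsulfanyl stood, on a carbon with a double bond to nitrogen, gave a 5.9-fold lower number from compound 3 to compound 4 (0.77 log units; beyond the scatter). The exchange therefore lowered the number on both cores, and the two steps cannot be told apart in size, so in this small set the gain carried over from one core to the other: the same change on two cores in this assay, a 12-fold lower number (1.08 log units; beyond the scatter) from compound 2 to compound 1 and a 5.9-fold lower number (0.77 log units; beyond the scatter) from compound 3 to compound 4, 2.0-fold (0.30 log units) apart, within the scatter of two such steps This shows that the change behaved alike on the two cores tested, but two pairs cannot establish a rule for other cores, and these growth-inhibition numbers alone do not reveal why the selenium compounds give lower numbers than their sulfur partners.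

The compounds shown leave open whether a longer chain such as ethyl on the selenium would keep the lower number, and how an amine or a methoxy group would compare at the same place, on the carbon with a double bond to nitrogen. They also leave open whether the selenium-for-sulfur step holds on cores beyond these two, or on cells other than the ones tested here.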